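The source may report more compounds than this note shows. Statements on the series, on what has been measured and on what is new or still open speak of the compounds shown alone.

Of the compounds shown here, three have been measured in a functional assay on PC-3 cells (Homo sapiens) for antiproliferative activity, read by MTT assay; a lower number here means a stronger inhibitor, a higher number a weaker inhibitor. Compound 1 `COc1cc(-c2nnc(Sc3ncnc4ccccc34)s2)cc(OC)c1OC` gives 19000 nM and compound 2 `COc1cc(-c2nnc(Sc3ncnc4ccc(I)cc34)s2)cc(OC)c1OC` gives 12200 nM. The two differ in one place, (hydrogen in place of iodo on an aromatic carbon), and the step of a 1.6-fold higher number from compound 2 to compound 1 (0.19 log units; within the scatter) lies within the scatter. Compound 3 `C=CCSc1ncnc2ccc(I)cc12` gives 28800 nM; this number lies within the scatter of compound 1 and beyond the scatter of compound 2. The difference between the core of compound 3 and the core of compound 2 is not broken down here.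

Compound 4 `C=CCSc1ncnc2ccccc12` has not yet been measured in this assay. It differs from compound 3 by hydrogen in place of iodo on an aromatic carbon. For the measured compounds named here, the place description reads the same word for word as the one for the change from compound 2 to compound 1, so this is the same change made on a different core. Going by the values given here, the only measured guide to its size is a 1.6-fold higher number from compound 2 to compound 1 (0.19 log units; within the scatter), a step that stayed within the scatter. For compound 4 the expected step is a 1.6-fold higher number from compound 3 to compound 4 (0.19 log units; within the scatter), which would also stay within the scatter. Compound 4 is therefore estimated to give about 45000 nM in this assay, with a range from 20000 nM to 100000 nM. Because compound 3 gives 28800 nM, a number already far toward the weak end, compound 4 is expected to sit toward the weak end as well.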

Compound 4, half-maximal inhibitory concentration: 48000 nM
Compound 4: the middle estimate sits 1.1-fold (0.03 log units) below what was measured; the measured number falls inside the stated range.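

In this assay the change from iodo to hydrogen on the core of compound 3 gives a 1.7-fold higher number from compound 3 to compound 4 (0.22 log units; within the scatter). Set beside the earlier step, the same change comes out at about the same size on the two cores: the same change on two cores in this assay, a 1.6-fold higher number (0.19 log units; within the scatter) from compound 2 to compound 1 and a 1.7-fold higher number (0.22 log units; within the scatter) from compound 3 to compound 4, 1.1-fold (0.03 log units) apart, within the scatter of two such steps Each step on its own lies within the scatter, so the two agree on a small step and do not establish a firm effect of the iodo on either core, and two cores say nothing about any further core in the series.

The compounds shown carry only iodo or hydrogen on this aromatic carbon, so it remains open whether another group there, such as an amine or a carboxylic acid, would move the number beyond the scatter. For the compounds shown here, it also remains open how the rest of the molecule contributes, for instance whether a longer chain in place of the one on compound 3 and compound 4 would change the number, or whether the step from iodo to hydrogen would stay the same size on such a compound.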